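A few compounds are considered here, and "the series" means these few. Any claim that something is new, unique, unknown or untested is made for them only; others in the source may bear on it.

In an ADME assay on BJ cells (Homo sapiens) for cytotoxicity, with a stated time of 72 h (a lower number here means that less compound is needed, a higher number that more compound is needed for the effect), compound 1 (`Cc1cc(NC(=O)Nc2ccccc2N)c2ccccc2n1`) gives > 25000 nM, which is a limit and not a number. Compound 2 (`Cc1cc(NC(=O)Nc2ccc(F)cc2)c2ccccc2n1`), which has no amino group, gives > 25000 nM, which is likewise a limit. The two compounds therefore stand together at the limit of > 25000 nM in this assay, at which 2 of the 2 values shown sit. Going by the values given here, the only measured step is a step that the two limits leave unreadable from compound 1 to compound 2, so it offers no size to carry forward. Compound 3 (`CSc1ccccc1NC(=O)Nc1cc(C)nc2ccccc12`) keeps the core of compound 1 and carries methylsulfanyl in place of amino on an aromatic carbon. Among the compounds with values here, no measured step makes this exact exchange, and the nearest guide is that compound 2 lost the amino group and still gave > 25000 nM, again a limit. A change beyond the usual scatter is not expected, and the estimated step is a number no higher from compound 1 to compound 3 (the limit leaves the size open). For compound 3 the expected value is 25000 nM, within an estimated range of 12000 nM to 40000 nM.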

Compound 3, half-maximal effective concentration: > 25000 nM
Compound 3: only a limit was reported; the forecaster's own chance of this, stated with the estimate: 80%; the middle value lies on the limit itself.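

In this assay compound 3 gives > 25000 nM, which is a limit and not a number. No step between compound 1 and compound 3 can be read, as both values are limits: the limit of > 25000 nM in this assay, at which 3 of the 3 values shown sit.

The compounds shown leave open what the half-maximal effective concentration of any of the three compounds actually is.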